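Removing a Methyl from the Ring of Compound 2

The source may report more compounds than this note shows. Statements on the series, on what has been measured and on what is new or still open speak of the compounds shown alone.

Compound 1, `N/C(=N\NC(=S)N1CCCCC1)c1ccccn1`: 27%
Compound 2, `Cc1cccc(/C(N)=N/NC(=S)N2CCCC2)n1`: 47.2%

These two compounds were tested in a functional assay on A-431 cells (Homo sapiens) for cytotoxicity, read by MTT assay, with a stated time of 72 h, tested at 3 uM; a higher number here means more inhibition of growth at the concentration tested, a lower number less inhibition of growth. Compound 2 stands higher of the two, and its gap to compound 1 lies beyond the usual scatter. Compound 3, `N/C(=N\NC(=S)N1CCCC1)c1ccccn1`, has not been measured. It differs from compound 2 by hydrogen in place of methyl on an aromatic carbon, on an aromatic carbon of a six-membered aromatic ring with 1 nitrogen, next to the ring nitrogen. Within the data shown here, no measured pair shows this exact change, so the size of the step is open; a modest drop is expected, near the edge of the scatter, since compound 1, which also lacks the methyl, gives 27%. The expected step is a number 11.2 percentage points lower from compound 2 to compound 3 (beyond the scatter), and compound 3 is estimated at 36%, with a range from 18% to 54%.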

Compound 3, percent growth inhibition at one concentration: 70.9%
Compound 3: middle estimate off by 34.9 percentage points, on the low side, outside the stated range (above it).
By their numbers in this assay, from the lowest: compound 1; then compound 2; then compound 3.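

In this assay, hydrogen in place of methyl on the aromatic carbon next to the ring nitrogen gives a number 23.7 percentage points higher from compound 2 to compound 3 (beyond the scatter), so the methyl is not needed for growth inhibition at this position. Pyrrolidin-1-yl in place of piperidin-1-yl on the thiocarbonyl carbon gives a number 43.9 percentage points higher from compound 1 to compound 3 (beyond the scatter), so the group on that carbon also matters. No measurement here explains either step.

From the compounds shown here alone, whether a fluorine, a methoxy group or an amine at the same ring position would match hydrogen remains open. Also open, going by these compounds, is whether removing the methyl gives a similar step when piperidin-1-yl sits on the thiocarbonyl carbon.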